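Halogen exchange on the phenoxy ring of compound 1

The source may hold more compounds than are shown below. What is called first, only, known or untested is meant among the compounds shown, and "the series" means these compounds.

Within the data shown here, compound 1 `CSc1cc(C)nc(SC)c1NC(=O)N(Cc1ccccc1)Cc1ccc(Oc2ccc(F)cc2)cc1` gives 9.1 nM in an assay for inhibition of acyl-CoA:cholesterol acyltransferase (Oryctolagus cuniculus), using microsomes (on this read-out lower numbers stand for stronger inhibition and higher numbers for weaker inhibition), the lowest of the two numbers measured so far. Among the measured compounds shown here, its only neighbour is compound 2 `CSc1cc(C)nc(SC)c1NC(=O)N(CCCc1ccccc1)Cc1ccc(Oc2ccc(F)cc2)cc1`, which gives 28 nM in this assay; the step of a 3.1-fold higher number from compound 1 to compound 2 (0.49 log units; beyond the scatter) alters the chain on the amide-type nitrogen and leaves the phenoxy ring untouched. Compound 3 `CSc1cc(C)nc(SC)c1NC(=O)N(Cc1ccccc1)Cc1ccc(Oc2ccc(Br)cc2)cc1` differs from compound 1 by bromo in place of fluoro on an aromatic carbon, sitting on an aromatic carbon of a six-membered aromatic ring of carbon only, para to a large group. For the measured compounds named here, no measured step exchanges one halogen for another at this place. The step of a 3.1-fold higher number from compound 1 to compound 2 (0.49 log units; beyond the scatter) therefore bears on it only as a gauge of how far this series moves under a modest change elsewhere; it gives no direction for the halogen exchange. With nothing pointing either way, a step of a 1.0-fold lower number from compound 1 to compound 3 (0.00 log units; within the scatter) within the scatter is expected. Compound 3 is estimated at 9 nM in this assay, with the range expected to run from 3 nM to 27 nM.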

Compound 3, half-maximal inhibitory concentration: 10 nM
For compound 3 the middle estimate is 1.1-fold (0.05 log units) below the measured one, within the range that was stated.
By their numbers in this assay, from the lowest: compounds 1 and 3 (each within the scatter of the next); then compound 2.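

Working notes, phenoxy ring. In this assay, among these compounds, the exchange of 4-fluorophenoxy for 4-bromophenoxy gives a 1.1-fold higher number from compound 1 to compound 3 (0.04 log units; within the scatter) and is the first reading at this place, on an aromatic carbon para to a large group, where fluoro and bromo cannot be told apart on this read-out. Among the compounds shown here, the only earlier step, a 3.1-fold higher number from compound 1 to compound 2 (0.49 log units; beyond the scatter), lies at the chain on the amide-type nitrogen and is beyond the scatter, so within these three compounds that chain registers on the read-out while this halogen exchange does not. No supporting measurement is available to account for the match between the two halogens.

With only two halogens at this place, the reading says nothing yet about chloro or about non-halogen groups such as methoxy, trifluoromethyl, a carboxylic acid or an amine, any of which could separate from fluoro and bromo on this read-out. Going by these compounds, it also remains open whether bromo would match fluoro in the same way on the longer phenethyl-type chain of compound 2, since that compound is known here only with fluoro.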